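From Compound 2 to Compound 3: An Expected Affinity

The source may hold more compounds than are shown below. What is called first, only, known or untested is meant among the compounds shown, and "the series" means these compounds.

Compound 1 `CCn1ncc2c(F)cc(-c3ccc(C(CC)(CC)c4ncn(C)n4)c(=O)[nH]3)cc21` and compound 2 `CC(C)C(c1ccc(-c2ccc3cccc(F)c3c2)[nH]c1=O)N1CCNC1=O` were both tested in an assay on CHO cells for displacement of a labelled ligand from prostaglandin E2 receptor EP3 subtype (Homo sapiens), read by radioligand binding; on this read-out higher numbers stand for weaker inhibition and lower numbers for stronger inhibition. In this assay compound 1 gives 39 nM, and compound 2 gives 9.1 nM, the lower of the two numbers, with the gap between them beyond the usual scatter. Compound 3 `CC(C)C(c1ncco1)c1ccc(-c2ccc3cccc(F)c3c2)[nH]c1=O` has not yet been measured. It differs from compound 2 in one place: 1,3-oxazol-2-yl in place of 2-oxoimidazolidin-1-yl on a saturated chain carbon bound to an aromatic carbon and a saturated chain carbon. Among the measured compounds shown here, no measured pair shows this change, so its effect is unknown from the data. A modest weakening is expected, a 2.2-fold higher number from compound 2 to compound 3 (0.34 log units; beyond the scatter). Compound 3 is therefore expected to give 20 nM, within 6 nM to 70 nM.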

Compound 3, inhibition constant: 24 nM
Compound 3: the middle estimate sits 1.2-fold (0.08 log units) below what was measured; measured number inside the range.
By their numbers in this assay, from the lowest: compound 2; then compounds 3 and 1 (each within the scatter of the next).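

In this assay, 1,3-oxazol-2-yl in place of 2-oxoimidazolidin-1-yl on this saturated chain carbon brings a 2.6-fold higher number from compound 2 to compound 3 (0.42 log units; beyond the scatter). This first reading at the position shows that an aromatic five-membered ring without hydrogen-bond donors can stand there at only a modest cost. Nothing measured here accounts for the step. From the compounds shown here alone, what an amine or a carboxylic acid would do at this place stays open. A single pair also cannot separate the loss of the hydrogen-bond donor from the change of ring.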